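The compounds below may be only part of what the source reports. "The series", "measured", "known", "first", "only" and "open" are said of these compounds alone.

Compounds measured so far:
- compound 1 `CCC(NC(=O)C(CC(C)C)NC(=O)OCc1ccccc1)C(=O)C(=O)NCc1ccccc1`: 200 nM
- compound 2 `CCC(NC(=O)C(CC(C)C)NC(=O)OCc1ccccc1)C(=O)C(=O)NCc1ccc2ccccc2n1`: 130 nM

For the measured compounds named here, in an assay on isolated protein for inhibition of Calpain-1 catalytic subunit (Homo sapiens) (a lower number here means a stronger inhibitor, a higher number a weaker inhibitor), compound 2 gives the lowest of the two numbers so far, but compound 1 sits a step away that is within the scatter, so neither can be called the stronger inhibitor. Going by the values given here, the one measured step, a 1.5-fold lower number from compound 1 to compound 2 (0.19 log units; within the scatter), is the only one that bears on the next change, and it was small.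

Compound 3 `CCC(NC(=O)C(CC(C)C)NC(=O)OCc1ccccc1)C(=O)C(=O)NCc1nccc2ccccc12` is built from compound 2 by a change of the same kind: isoquinolin-1-yl in place of quinolin-2-yl on a saturated chain carbon bound to an amide-type nitrogen. The two have the same atoms joined differently. On the basis of compound 2 and of a 1.5-fold lower number from compound 1 to compound 2 (0.19 log units; within the scatter), no step beyond the scatter is expected in this assay, in either direction; the expected step is a 1.2-fold higher number from compound 2 to compound 3 (0.06 log units; within the scatter). Compound 3 is therefore estimated at 150 nM, with a range from 60 nM to 400 nM.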

Compound 3, inhibition constant: 250 nM
For compound 3 the middle estimate is 1.7-fold (0.22 log units) below the measured one; the measured number falls inside the stated range.
By their numbers in this assay, from the lowest: compounds 2, 1 and 3 (each within the scatter of the next).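

In this assay, isoquinolin-1-yl in place of quinolin-2-yl on a saturated chain carbon bound to an amide-type nitrogen gives a 1.9-fold higher number from compound 2 to compound 3 (0.28 log units; within the scatter), and isoquinolin-1-yl in place of phenyl at the same place gives a 1.3-fold higher number from compound 1 to compound 3 (0.10 log units; within the scatter). Joining the same atoms differently in this group therefore produces no step beyond the scatter, and the phenyl, quinolin-2-yl and isoquinolin-1-yl compounds cannot be told apart by their numbers, so this position has not yet shown a measurable preference among these three groups. No evidence is available that bears on why the numbers fall as they do.

As far as these compounds go, all three groups contain an aromatic ring, so it remains open whether any other kind of group at this place would produce a step beyond the scatter. An amine, a carboxylic acid or a longer chain in place of these rings could answer that question.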